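The compounds below may be only part of what the source reports. "The series", "measured", "known", "first", "only" and "open" are said of these compounds alone.

Measured compounds:
compound 1, `C#CCN(CCCOc1ccc2ccc(=O)oc2c1)Cc1ccc(C(C)C)cc1`, 77400 nM
compound 2, `C#CCN(CCCCOc1ccc2ccc(=O)oc2c1)Cc1cccc(F)c1`, 69200 nM

In an ADME assay on isolated protein for inhibition of Amine oxidase [flavin-containing] A (Homo sapiens), read by fluorescence and Amplex Red, with stated times of 15 min and 20 min (on this read-out higher numbers stand for weaker inhibition and lower numbers for stronger inhibition), compound 1 gives the higher of the two numbers, but compound 2, whose value is 69200 nM, sits within the usual scatter of it, so the two compounds cannot be told apart on this read-out. Both are weak inhibitors of the enzyme.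

Compound 3, `C#CCN(CCCOc1ccc2ccc(=O)oc2c1)Cc1cccc(OC)c1`, has not yet been measured in this assay. It differs from compound 1 in one place: 3-methoxyphenyl in place of 4-isopropylphenyl on a saturated chain carbon bound to an amine nitrogen. No measured pair differs in this way, so nothing shown tells how such a change moves the number. With compound 1 at 77400 nM and compound 2 in the same range, compound 3 is expected to stay near them; the step of a 1.2-fold lower number from compound 1 to compound 3 (0.08 log units; within the scatter) is estimated to lie within the scatter, with no direction that the data can support. Compound 3 is accordingly expected to give about 65000 nM, in a range from 20000 nM to 200000 nM.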

Compound 3, half-maximal inhibitory concentration: 22700 nM
The estimate for compound 3 lay 2.9-fold (0.46 log units) above the measured number; low and high end bracket the measured number.
By their numbers in this assay, from the lowest: compound 3; then compounds 2 and 1 (each within the scatter of the next).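

For the compounds shown here, the aryl group on a saturated chain carbon bound to an amine nitrogen is not silent in this assay: 3-methoxyphenyl in place of 4-isopropylphenyl gives a 3.4-fold lower number from compound 1 to compound 3 (0.53 log units; beyond the scatter), the only step here that can be read. The entering group has 8 heavy atoms, one of them oxygen, and 1 hydrogen-bond acceptor, against 9 carbon atoms and no acceptor in the group it replaces, but one step cannot show which of these differences matters. Nothing available explains the shift.

From the compounds shown here alone, it remains open whether the step follows from gaining the methoxy group or losing the isopropyl group, which a plain phenyl, a 4-methoxyphenyl or a 3-isopropylphenyl at this place could separate. Going by these compounds, compound 2 differs from compound 3 in more than one place, so whether a longer chain alters this step also stays unknown.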